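A few compounds are considered here, and "the series" means these few. Any claim that something is new, unique, unknown or untested is made for them only; others in the source may bear on it.

Measured compounds:
compound 1 `Cc1ccc2nc(-c3ccc(N(C)C)cc3)c(NC3CCCCC3)n2c1`: > 50000 nM
compound 2 `c1ccc(-c2nc3ccccn3c2NCC2CCO2)nc1`: > 50000 nM

Cell tolerance is the only read-out here, and it is measured in an ADME assay on THP-1 cells (Homo sapiens) for cytotoxicity; a lower number here means that less compound is tolerated, a higher number that more compound is tolerated. In this assay compound 2 gives > 50000 nM, which is a limit of the assay and not a number. Compound 1 gives > 50000 nM, which is also a limit. The whole picture so far is therefore (the limit of > 50000 nM in this assay, at which 2 of the 2 values shown sit). Going by the values given here, neither compound has a true number, so no measured step is available to guide the next prediction.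

Compound 3 `Fc1cccc(Nc2c(-c3ccccn3)nc3ccccn23)c1` keeps the core of compound 2 but carries 3-fluorophenyl in place of (oxetan-2-yl)methyl on a nitrogen on an aromatic ring.

The expectation for this swap rests on compound 2, with its limit of > 50000 nM, and on compound 1 showing the same limit with a different substituent. No step beyond the scatter is expected in this assay, and any real movement is expected to be modest and towards a lower number. The estimated change is an at least 1.1-fold lower number from compound 2 to compound 3 (0.04 log units; that floor lies within the scatter). For compound 3 the expected value is 45000 nM, with an estimated range of 15000 nM to 100000 nM.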

Compound 3, half-maximal cytotoxic concentration: > 50000 nM
Compound 3: only a limit was reported; the forecaster's own chance of this, stated with the estimate: 60%; middle value at least 1.1-fold (0.04 log units) away from the limit.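

In this assay compound 3 gives > 50000 nM, which is a limit of the assay and not a number. Going by these compounds alone, compound 2 also sits at a limit, so no step from compound 2 to compound 3 can be read. The picture stays the same: the limit of > 50000 nM in this assay, at which 3 of the 3 values shown sit. The compounds shown leave open what true number any of them would give in this assay.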